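Phenyl in Place of 3,4-Difluorophenyl on the Ring Nitrogen

A few compounds are considered here, and "the series" means these few. Any claim that something is new, unique, unknown or untested is made for them only; others in the source may bear on it.

Measured compounds:
Compound 1 `Cc1c(/C=N\O)cc(-c2ccc(S(C)(=O)=O)cc2)n1-c1ccc(F)c(F)c1` gives 27%
Compound 2 `Cc1c(/C=N\O)cc(-c2ccc(S(C)(=O)=O)cc2)n1-c1ccccc1` gives 53%
Compound 3 `Cc1c(C#N)cc(-c2ccc(S(C)(=O)=O)cc2)n1-c1ccc(F)c(F)c1` gives 38%

These three compounds were tested in a functional assay on the whole organism (strain Swiss albino) for inhibition, with Mus musculus as the target, in the writhing test, with a stated time of 30 min, at a dose of 20 mg/kg by the oral route; a lower number here means a weaker effect, a higher number a stronger effect of the compound at the dose given. They share a core in which the substituent on the aromatic nitrogen and the group on one aromatic carbon vary.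

From compound 1 to compound 2 the change is phenyl in place of 3,4-difluorophenyl on an aromatic nitrogen and it produced a number 26 percentage points higher from compound 1 to compound 2 (beyond the scatter). Compound 3 differs from compound 1 in the core itself: a group of 2 heavy atoms (1 carbon, 1 nitrogen; no ring) in place of a group of 3 heavy atoms (1 carbon, 1 nitrogen, 1 oxygen; no ring), on an aromatic carbon, with a number 11 percentage points higher from compound 1 to compound 3 (beyond the scatter). Compound 3 thus stands second of the three numbers.

Compound 4 `Cc1c(C#N)cc(-c2ccc(S(C)(=O)=O)cc2)n1-c1ccccc1` has not yet been measured in this assay. It arises from compound 3 by phenyl in place of 3,4-difluorophenyl on an aromatic nitrogen. This is the same kind of change as that from compound 1 to compound 2, but the surroundings are not identical: in the earlier pair the place lies two ring bonds from the ring atom that bears a group of 3 heavy atoms, whereas here it lies two ring bonds from the ring atom that bears a cyano group (2 heavy atoms).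

Among the measured compounds shown here, for compound 4 the expected step is a number 24 percentage points higher from compound 3 to compound 4 (beyond the scatter), set beside the earlier a number 26 percentage points higher from compound 1 to compound 2 (beyond the scatter), since this single measured pair is the only guide and the core change itself gave a modest step. Compound 4 is accordingly estimated at 62%, within the range 48% to 76%.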

Compound 4, a percentage reported as inhibition, in the whole organism at one dose (the size of the read-out at that dose, not a potency): 42%
Beside the measured number, compound 4's estimate is 20 percentage points above it; the measured number lies below the stated range.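

Phenyl in place of 3,4-difluorophenyl on the aromatic nitrogen gave, in this assay, a number 4 percentage points higher from compound 3 to compound 4 (within the scatter), and this step does not match the one seen on the core of compound 1: the same change on two cores in this assay, a number 26 percentage points higher (beyond the scatter) from compound 1 to compound 2 and a number 4 percentage points higher (within the scatter) from compound 3 to compound 4, 22 percentage points apart, beyond the scatter of two such steps. The reverse comparison tells the same story, since the cyano group in place of the group of 3 heavy atoms on the aromatic carbon gave a number 11 percentage points lower from compound 2 to compound 4 (beyond the scatter) with phenyl on the nitrogen, and the same change ran the opposite way with 3,4-difluorophenyl there: the same change on two cores in this assay, a number 11 percentage points higher (beyond the scatter) from compound 1 to compound 3 and a number 11 percentage points lower (beyond the scatter) from compound 2 to compound 4, 22 percentage points apart, beyond the scatter of two such steps. This shows that within these four compounds the effect of either change depends on the other, so a step measured on one core cannot simply be carried to the other, but it does not show why the steps differ or whether the same dependence holds for any other pair of groups.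

The compounds shown leave open how a benzyl group on the aromatic nitrogen, or a carboxylic acid or an amide on the aromatic carbon, would behave on these cores. They also leave open what a longer chain in place of the methyl group would do to either step.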